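Moving the Methyl on the Amide Aryl Ring

The source may hold more compounds than are shown below. What is called first, only, known or untested is meant among the compounds shown, and "the series" means these compounds.

Compound 3 `COc1ccc2occ(C(=O)Nc3cccc(C)c3)c(=O)c2c1` was tested in an assay on cells for inhibition of Amine oxidase [flavin-containing] B (Homo sapiens), read by fluorescence and Amplex Red, using microsomes, with a stated time of 15 min (a lower number here means a stronger inhibitor, a higher number a weaker inhibitor), and gave 21.8 nM. Among the three measured compounds it stands second highest: compound 1 `Cc1cccc(NC(=O)c2coc3ccc(C)cc3c2=O)c1` gives 17.1 nM, a value within the scatter of compound 3, and compound 2 `Cc1ccc2occ(C(=O)Nc3ccc(Cl)cc3)c(=O)c2c1` gives 45.4 nM. Compound 4 `COc1ccc2occ(C(=O)Nc3ccc(C)cc3)c(=O)c2c1` differs from compound 3 by 4-methylphenyl in place of 3-methylphenyl on an amide-type nitrogen. Going by the values given here, the only measured step that touches the group on the amide nitrogen is a 2.7-fold higher number from compound 1 to compound 2 (0.42 log units; beyond the scatter), where a different ring entered and the number rose modestly. The step of a 1.3-fold higher number from compound 1 to compound 3 (0.11 log units; within the scatter) concerns another part of the molecule. A methyl shifted within the same ring is a smaller change than that, so only a modest step is expected, a 1.6-fold higher number from compound 3 to compound 4 (0.21 log units; within the scatter). Compound 4 is therefore estimated at 35 nM in this assay, within 15 nM to 80 nM.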

Compound 4, half-maximal inhibitory concentration: 211 nM
Compound 4: middle estimate off by 6.0-fold (0.78 log units), on the low side, outside the stated range (above it).
By their numbers in this assay, from the lowest: compounds 1 and 3 (each within the scatter of the next); then compound 2; then compound 4.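

In this assay the two groups hold the same atoms, yet 4-methylphenyl in place of 3-methylphenyl on the amide-type nitrogen gives a 9.7-fold higher number from compound 3 to compound 4 (0.99 log units; beyond the scatter). This position therefore responds strongly to where the methyl sits on the ring, not only to which atoms are present. No measurement here explains this difference. The compounds shown leave open whether a longer chain or an amine on this ring would give a similar rise. They also leave open whether the same methyl shift would have a similar effect on the core of compound 1.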